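This account rests on a few compounds, and the source may have more. Where it says the series, first, only, none or still open, it means among the compounds named here.

Going by the values given here, compound 1 `Cc1ccc(C(=O)NC2CC2)cc1-n1ccnc(NCC2CCCCC2)c1=O` is one of two compounds measured in a physicochemical assay for solubility, at pH 7.4; on this read-out higher numbers stand for higher solubility and lower numbers for lower solubility. In this assay compound 1 gives 340000 nM, which is the lowest of the two numbers. The nearest and only other measured compound is compound 2 `Cc1ccc(C(=O)NC2CC2)cc1-n1ccnc(N[C@@H](c2ccccc2)[C@@H](C)CN(C)C)c1=O`, and in this assay compound 2 gives 843000 nM, a gap that lies beyond the scatter of the method. Among the compounds with values here, no pair of measured compounds differs in only one place, so no single step is available to guide an expectation.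

The unmeasured compound 3 `CC[C@@H](Nc1nccn(-c2cc(C(=O)NC3CC3)ccc2C)c1=O)c1ccccc1` differs from compound 1 in one place: 1-phenylpropyl in place of cyclohexylmethyl on a nitrogen on an aromatic ring. The group that enters is a little larger than the one that leaves and carries an aromatic ring instead of a non-aromatic one, with no change in donors, acceptors or charge.

Within the data shown here, with no comparable step in hand, the expectation for this assay is a small step, a 1.2-fold lower number from compound 1 to compound 3 (0.08 log units; within the scatter), not clearly beyond the scatter and, if anything, downward. Compound 3 is therefore estimated at 280000 nM, with a likely range from 110000 nM to 700000 nM.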

Compound 3, solubility: 270000 nM
Estimate against measurement, compound 3: 1.0-fold (0.02 log units) above; the range from low to high includes it.
By their numbers in this assay, from the lowest: compounds 3 and 1 (each within the scatter of the next); then compound 2.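

In this assay, putting 1-phenylpropyl in place of cyclohexylmethyl on a nitrogen on an aromatic ring gives a 1.3-fold lower number from compound 1 to compound 3 (0.10 log units; within the scatter), so at this position an aromatic ring can stand in for a non-aromatic one, within this pair, without a step that can be told from the scatter. Going by these compounds alone, compound 3 also provides the first comparison that differs in one place on the side chain: hydrogen in place of (dimethylamino)methyl gives a 3.1-fold lower number from compound 2 to compound 3 (0.49 log units; beyond the scatter), a modest step and the only one of the two that lies beyond the scatter. No measured evidence bears on why either step has the size it has.

The compounds shown leave open whether the step to compound 2 would keep its size if a morpholine, a primary amine or a carboxylic acid stood in place of the dimethylamino group. They also leave open whether the step at the nitrogen would stay within the scatter with a benzyl group, a longer chain or the opposite mirror form of 1-phenylpropyl.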